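Cytotoxicity series: methoxy to fluoro step on compound 3

The source may report more compounds than this note shows. Statements on the series, on what has been measured and on what is new or still open speak of the compounds shown alone.

Measured so far:
compound 1 `O=C(CSc1nnnn1-c1ccccc1)N/N=c1/scc(-c2ccc(F)cc2)n1-c1ccccc1` gives 30.6% in a functional assay on C6 cells (Rattus norvegicus) for cytotoxicity, read by MTT assay, with a stated time of 24 h, tested at 200 ug/mL; on this read-out lower numbers stand for a stronger effect and higher numbers for a weaker effect at the one concentration tested
compound 2 `Cc1ccc(-c2cs/c(=N/NC(=O)CSc3ncccn3)n2-c2ccccc2)cc1` gives 43.7%
compound 3 `COc1ccc(-c2cs/c(=N/NC(=O)CSc3ncccn3)n2-c2ccccc2)cc1` gives 37.6%

Compound 3 carries the same shared core as compound 2 and the same thioether-linked heteroaromatic group; the pair differs only in the group on the pendant phenyl ring. The step of a number 6.1 percentage points lower from compound 2 to compound 3 (within the scatter) is within the scatter, so the two compounds cannot be told apart on the numbers shown. Compound 3 stands second highest of the three, with compound 2 nearest and compound 1 furthest, and both of those gaps are also within the scatter. Among the compounds with values here, compound 1 carries the fluoro group but a different heteroaromatic ring on the thioether, so no single-point step links it to compound 3.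

Compound 4 `O=C(CSc1ncccn1)N/N=c1/scc(-c2ccc(F)cc2)n1-c1ccccc1` differs from compound 3 in one place: fluoro in place of methoxy on an aromatic carbon. Cut one bond further out, the change reads 4-methoxyphenyl to 4-fluorophenyl. Within the data shown here, the only measured step on that phenyl ring, methoxy for methyl, was within the scatter, and compound 1, the sole fluoro-bearing compound, sits within the scatter of compound 3. No step beyond the scatter is therefore expected: the estimated step of a number 3.6 percentage points lower from compound 3 to compound 4 (within the scatter) is small. Compound 4 is expected to give about 34% in this assay, within the range 22% to 46%.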

Compound 4, a percentage reported as activity, at one concentration (the size of the read-out at that concentration, not a potency): 32.2%
The estimate for compound 4 lay 1.8 percentage points above the measured number; low and high end bracket the measured number.
By their numbers in this assay, from the lowest: compounds 1, 4, 3 and 2 (each within the scatter of the next, the first and the last beyond it).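

In this assay, fluoro in place of methoxy on an aromatic carbon para to a large group comes with a number 5.4 percentage points lower from compound 3 to compound 4 (within the scatter), so these two groups cannot be told apart at this position. Fluoro in place of methyl at the same position gives a number 11.5 percentage points lower from compound 2 to compound 4 (beyond the scatter), the only modest step on this ring among the pairs shown, so the position is not wholly indifferent to its substituent, although the methoxy compound 3 cannot be separated from either neighbour. Within the data shown here, with the 4-fluorophenyl group held constant, the first single-point comparison at the sulfur, pyrimidin-2-yl in place of 1-phenyl-1H-tetrazol-5-yl, gives a number 1.6 percentage points higher from compound 1 to compound 4 (within the scatter), so the two sulfur substituents cannot be told apart with this phenyl group in place.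

Open, going by these compounds, is how the position responds to groups other than methyl, methoxy and fluoro, such as an amine, a carboxylic acid or a longer chain, and whether the match between the two sulfur substituents holds when the phenyl ring carries something other than fluoro. No evidence at hand bears on what lies behind the modest step between the methyl and fluoro compounds.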